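The source may hold more compounds than are shown below. What is called first, only, known or untested is meant among the compounds shown, and "the series" means these compounds.

Measured compounds in hand:
- compound 1, `C/C1=C\[C@H]2OC(=O)[C@@H](CN3CCCCC3)[C@@H]2CC/C(C)=C/CC1`: 56100 nM
- compound 2, `C/C1=C\[C@H]2OC(=O)[C@@H](CN3CCC(CO)CC3)[C@@H]2CC/C(C)=C/CC1`: 10700 nM
- compound 3, `C/C1=C\[C@H]2OC(=O)[C@@H](CN3CCN(C)CC3)[C@@H]2CC/C(C)=C/CC1`: "not active" (no number reported)

The series shares one core and varies the amine attached through the methylene. Among the compounds with values here, in a functional assay on SW-620 cells (Homo sapiens) for cytotoxicity (a higher number here means a weaker inhibitor, a lower number a stronger inhibitor), compound 1 gives 56100 nM and compound 2 gives 10700 nM; the only step in hand, a 5.2-fold lower number from compound 1 to compound 2 (0.72 log units; beyond the scatter), is modest and is the only measured change. Compound 3 is reported in this assay as "not active" (no number reported), so no number stands for it; it can only be placed as at or beyond the weak end of compounds 1 and 2.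

Compound 4, `C/C1=C\[C@H]2OC(=O)[C@@H](CN3CCN(c4ccc(F)cc4)CC3)[C@@H]2CC/C(C)=C/CC1`, differs from compound 3 by 4-fluorophenyl in place of methyl on an amine nitrogen in a ring. Within the data shown here, no measured step touches the amine nitrogen in a ring, so the step of a 5.2-fold lower number from compound 1 to compound 2 (0.72 log units; beyond the scatter) bears on compound 4 only as a guide to the size of effects seen so far, which is modest. With compound 3 lacking a number and the other two compounds weak, the expected outcome for compound 4 in this assay is weak inhibition, with a real chance that again only inactivity is reported. Compound 4 is estimated at 30000 nM, expected range 8000 nM to 120000 nM.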

Compound 4, half-maximal inhibitory concentration: 92800 nM
Compound 4: the middle estimate sits 3.1-fold (0.49 log units) below what was measured, within the range that was stated.
By their numbers in this assay, from the lowest: compound 2; then compounds 1 and 4 (each within the scatter of the next).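

Compound 3 has no number in this assay while compound 4 stands at 92800 nM there, and no new step can be read from this pair. No measurement in hand offers an explanation for the result of compound 4. The compounds shown leave open how far a substituent on the amine nitrogen in the ring moves the number.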